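The compounds below may be only part of what the source reports. "The series", "measured", "known", "first", "only" and "open" are said of these compounds alone.

Compound 1 `Nc1ncnc2ncn(CCO)c12` — > 100000 nM
Compound 2 `Nc1ncnc2c1nc(Br)n2CCCO` — 3200 nM

Of the compounds shown here, two have so far been tested in an assay on CHO cells for displacement of a labelled ligand from adenosine receptor A3 (Homo sapiens); on this read-out lower numbers stand for stronger inhibition and higher numbers for weaker inhibition. Compound 1 reaches only a limit of the assay, > 100000 nM, which is a boundary and not a measured number. Compound 1 therefore sits at the limit of > 100000 nM in this assay, at which 1 of the 2 values shown sits. Going by the values given here, compound 2 gives 3200 nM in this assay, and this is the only real number in the set; compound 2 is thus the single fixed point from which any expectation must start.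

Compound 3 `C=CCCn1c(Br)nc2c(N)ncnc21` keeps the core of compound 2 and changes one place on the chain: vinyl in place of hydroxymethyl on a saturated chain carbon, two bonds along the chain from an aromatic nitrogen. Among the compounds with values here, no step between two measured compounds follows this kind of change, so the size of the shift cannot be read off from anything seen here. In this assay a modest move toward lower numbers seems plausible for compound 3, though a step of a size within the usual scatter cannot be excluded.

Compound 3 is estimated at 1200 nM, between 250 nM and 6000 nM, which means an expected step of a 2.7-fold lower number from compound 2 to compound 3 (0.43 log units; beyond the scatter).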

Compound 3, inhibition constant: > 100000 nM
Compound 3: only a limit was reported; the forecaster's own chance of this, stated with the estimate: 10%; middle value at least 83-fold (1.92 log units) away from the limit.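

In this assay, going by these compounds alone, putting vinyl in place of hydroxymethyl on a saturated chain carbon, two bonds along the chain from an aromatic nitrogen, gives an at least 31-fold higher number from compound 2 to compound 3 (1.49 log units; beyond the scatter), the first single change in this set whose size can be judged. Compound 3 reaches only a limit of the assay and not a measured number: the limit of > 100000 nM in this assay, at which 2 of the 3 values shown sit. This shows that the end of the chain is not a passive part of the structure on this read-out, since exchanging just this group, with its one hydrogen-bond donor and one hydrogen-bond acceptor, is enough to lose any measurable value.

This single pair cannot say whether the hydroxyl oxygen matters through its presence or the double bond through its own, since the change removes one and adds the other at the same place. Going by these compounds, whether an amine, a methoxy group or a carboxylic acid at the end of the chain would keep a measurable value, or whether a plain saturated chain of the same length would behave like compound 3, stays open.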